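This account rests on a few compounds, and the source may have more. Where it says the series, first, only, none or still open, it means among the compounds named here.

For the measured compounds named here, in a functional assay on MV4-11 cells (Homo sapiens) for antiproliferative activity, read by resazurin assay, with a stated time of 72 h (on this read-out lower numbers stand for stronger inhibition of growth and higher numbers for weaker inhibition of growth), compound 1 (`CC(=O)N1CCN(c2ccc(Nc3nccc(-c4c[nH]c5ccccc45)n3)cc2)CC1`) gives 33 nM as the higher of the two numbers so far, and compound 2 (`CN1CCN(c2cccc(Nc3nccc(-c4c[nH]c5ncccc45)n3)c2)CC1`) gives 5 nM as the lower, a gap beyond the scatter. Compound 3 (`CC(=O)N1CCN(c2ccc(Nc3nccc(-c4nn(C)c5ccccc45)n3)cc2)CC1`) carries 1-methyl-1H-indazol-3-yl in place of 1H-indol-3-yl on an aromatic carbon of the core of compound 1 (1-methyl-1H-indazol-3-yl in place of 1H-indol-3-yl on an aromatic carbon). Going by the values given here, no measured step covers this change, so the size rests on the structural change alone: weaker growth inhibition beyond the scatter is expected, with a 4.5-fold higher number from compound 1 to compound 3 (0.66 log units; beyond the scatter) as the expected move. The estimated value for compound 3 is 150 nM (expected range 30 nM to 700 nM).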

Compound 3, concentration for 50% growth inhibition: 181 nM
The estimate for compound 3 lay 1.2-fold (0.08 log units) below the measured number; low and high end bracket the measured number.
By their numbers in this assay, from the lowest: compound 2; then compound 1; then compound 3.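

At this position, on an aromatic carbon next to the ring nitrogen, 1-methyl-1H-indazol-3-yl in place of 1H-indol-3-yl gives a 5.5-fold higher number from compound 1 to compound 3 (0.74 log units; beyond the scatter) in this assay, so the result in this assay depends on the group held here. The change swaps a group with 1 hydrogen-bond donor for one with 0 and adds a ring nitrogen and a methyl together, so the step cannot be assigned to any one of these. No measurement available bears on the reason for the step. For the compounds shown here, still open is where 1H-indazol-3-yl and 1-methyl-1H-indol-3-yl would fall, as each carries only one part of the change.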